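The source may hold more compounds than are shown below. What is called first, only, known or untested is meant among the compounds shown, and "the series" means these compounds.

Compound 3 `CN(C)CCn1cnnc1-c1cc(Oc2ccc(NC(=O)N/N=C/c3ccc(F)cc3F)cc2F)ccn1` is one of three close analogues that share a core and were tested in a functional assay on A549 cells (Homo sapiens) for cytotoxicity, read by MTT assay, with a stated time of 72 h; on this read-out higher numbers stand for weaker inhibition and lower numbers for stronger inhibition. Compound 1 `COc1ccc(OC)c(/C=N/NC(=O)Nc2ccc(Oc3ccnc(-c4nncn4CCN(C)C)c3)c(F)c2)c1` gives 1950 nM in this assay, compound 2 `CN(C)CCn1cnnc1-c1cc(Oc2ccc(NC(=O)N/N=C/c3ccc(F)cc3)cc2F)ccn1` gives 1790 nM, and compound 3 gives 1870 nM. On these numbers compound 3 sits second highest, nearest compound 1 and furthest from compound 2, yet every gap lies within the scatter. The swaps among them all sit on the same carbon: a 1.1-fold lower number from compound 1 to compound 2 (0.04 log units; within the scatter), a 1.0-fold lower number from compound 1 to compound 3 (0.02 log units; within the scatter) and a 1.0-fold higher number from compound 2 to compound 3 (0.02 log units; within the scatter). Compound 4 `CN(C)CCn1cnnc1-c1cc(Oc2ccc(NC(=O)N/N=C/c3ccc(Cl)cc3)cc2F)ccn1` makes one more swap there: 4-chlorophenyl in place of 2,4-difluorophenyl on a carbon with a double bond to nitrogen. All three earlier exchanges of this aromatic group stayed within the scatter. In this assay the step is therefore expected to be a 1.0-fold lower number from compound 3 to compound 4 (0.00 log units; within the scatter), nothing beyond the scatter. Compound 4 is estimated at 1850 nM, with a range from 900 nM to 3800 nM.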

Compound 4, half-maximal inhibitory concentration: 780 nM
The estimate for compound 4 lay 2.4-fold (0.38 log units) above the measured number, and the stated range ends above it.
By their numbers in this assay, from the lowest: compound 4; then compounds 2, 3 and 1 (each within the scatter of the next).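

At this carbon the aromatic group can matter after all in this assay: 4-chlorophenyl brings a 2.4-fold lower number from compound 3 to compound 4 (0.38 log units; beyond the scatter) together with a 2.3-fold lower number from compound 2 to compound 4 (0.36 log units; beyond the scatter) and a 2.5-fold lower number from compound 1 to compound 4 (0.40 log units; beyond the scatter) and so gives stronger inhibition than any of the three earlier groups. Compound 2 and compound 4 differ only by chloro in place of fluoro on an aromatic carbon, so exchanging that single atom is enough to move the number, which no exchange among compound 1, compound 2 and compound 3 did. Nothing available explains this step. As far as these compounds go, whether 4-bromophenyl or 4-methylphenyl on this carbon would match 4-chlorophenyl stays open, as does the effect of 2-chlorophenyl.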